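Fluoro for Hydrogen on the Aromatic Ring of Compound 1

The compounds below may be only part of what the source reports. "The series", "measured", "known", "first", "only" and "open" are said of these compounds alone.

Among the measured compounds shown here, compound 1 `C=CC[C@H]1C[C@]2([C@@H](C)Cc3ccc(OC)c(C)c3)OCOC2=CC1=O` holds the lower of the two numbers measured so far in a functional assay on NCI-H460 cells (Homo sapiens) for antiproliferative activity, with a stated time of 72 h (a higher number here means a weaker inhibitor, a lower number a stronger inhibitor), where compound 1 gives 630 nM. For the measured compounds named here, its only measured neighbour is compound 2 `C=CC[C@H]1C[C@]2([C@@H](C)Cc3ccc(OC)c(C(=O)NC)c3)OCOC2=CC1=O`, which in this assay gives 1100 nM; the step of a 1.7-fold higher number from compound 1 to compound 2 (0.24 log units; within the scatter) lies within the scatter, so the two cannot be ranked against each other.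

Compound 3 `C=CC[C@H]1C[C@]2([C@@H](C)Cc3cc(C)c(OC)cc3F)OCOC2=CC1=O` differs from compound 1 by fluoro in place of hydrogen on an aromatic carbon of the six-membered aromatic ring of carbon only, ortho to a large group, meta to the methoxy group and para to the methyl group.

Going by the values given here, no measured step touches this position. Among the compounds with values here, the single step that exists, from compound 1 to compound 2, changes a different ring carbon and stays within the scatter. On such a thin basis there is no reason to expect a step beyond the scatter in this assay in either direction. Compound 3 is therefore expected to give about 700 nM, with a range from 300 nM to 1700 nM. The expected step of a 1.1-fold higher number from compound 1 to compound 3 (0.05 log units; within the scatter) is accordingly small.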

Compound 3, half-maximal inhibitory concentration: 650 nM
Compound 3: middle estimate off by 1.1-fold (0.03 log units), on the high side; low and high end bracket the measured number.
By their numbers in this assay, from the lowest: compounds 1, 3 and 2 (each within the scatter of the next).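

In this assay, fluoro in place of hydrogen on this aromatic carbon, ortho to a large group, gives a 1.0-fold higher number from compound 1 to compound 3 (0.01 log units; within the scatter), so the two compounds cannot be told apart. Among the compounds shown here, until now no measured step touched this position, and the one step that did exist concerned a different ring carbon; this result shows that a single fluorine atom can stand on this carbon without a step beyond the scatter in this assay. Nothing available explains why this result came out as it did.

At this position the compounds shown offer only hydrogen and fluoro, so it remains open whether a chloro, a trifluoromethyl, a methoxy or an amine on the same carbon would also stay within the scatter or would move the number clearly in one direction. From the compounds shown here alone, it is also open whether fluoro on this carbon would give a similarly small step when the methyl group of compound 1 is replaced by the methylcarbamoyl group of compound 2.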